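This account rests on a few compounds, and the source may have more. Where it says the series, first, only, none or still open, it means among the compounds named here.

In a functional assay on C6 cells (Rattus norvegicus) for cytotoxicity, read by MTT assay, with a stated time of 24 h, tested at 200 ug/mL (on this read-out lower numbers stand for a stronger effect and higher numbers for a weaker effect at the one concentration tested), compound 3 `O=C(CSc1ncccn1)N/N=c1/scc(-c2ccc(Br)cc2)n1-c1ccccc1` gives 63.2%, the highest of the three numbers recorded, and its distance from each of the other two lies beyond the scatter. Compound 1 `Cc1ccc(-c2cs/c(=N/NC(=O)CSc3nnnn3-c3ccccc3)n2-c2ccccc2)cc1` gives 22.2%, and compound 2 `Cc1ccc(-c2cs/c(=N/NC(=O)CSc3nncn3C)n2-c2ccccc2)cc1` gives 27.8%. Among the compounds with values here, the one step measured between them, a number 5.6 percentage points higher from compound 1 to compound 2 (within the scatter), concerns the group on the sulfur, not the ring that changes here. Compound 4 `Cc1ccc(-c2cs/c(=N/NC(=O)CSc3ncccn3)n2-c2ccccc2)cc1` differs from compound 3 as methyl in place of bromo on an aromatic carbon. Within the data shown here, no measured step covers this change; compounds 1 and 2 carry the same 4-methylphenyl as compound 4 yet differ from it at the sulfur group, so they guide only loosely. A downward step of a number 15.2 percentage points lower from compound 3 to compound 4 (beyond the scatter) is expected with low confidence. For compound 4 a value of 48% is estimated, within 28% to 68%.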

Compound 4, a percentage reported as activity, at one concentration (the size of the read-out at that concentration, not a potency): 43.7%
The estimate for compound 4 lay 4.3 percentage points above the measured number, and the stated range covers the measured number.
By their numbers in this assay, from the lowest: compounds 1 and 2 (each within the scatter of the next); then compound 4; then compound 3.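

In this assay, the position para to a large group responds to the change of substituent: methyl in place of bromo gives a number 19.5 percentage points lower from compound 3 to compound 4 (beyond the scatter), a shift toward a stronger effect. With 4-methylphenyl held constant, the group on the sulfur also counts, since pyrimidin-2-yl gives a number 15.9 percentage points higher from compound 2 to compound 4 (beyond the scatter) and a number 21.5 percentage points higher from compound 1 to compound 4 (beyond the scatter), both shifts toward a weaker effect. Nothing available explains these steps. The compounds shown leave open how an amine or a methoxy group would read at this position. They also leave open whether the sulfur-group steps would hold with 4-bromophenyl.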